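Swapping a pyridyl amide for a methoxyphenyl amide

The source may report more compounds than this note shows. Statements on the series, on what has been measured and on what is new or still open speak of the compounds shown alone.

Measured so far:
compound 1, `CCN1CCN(c2cc(C)c3cc(NC(=O)c4cccnc4)ccc3n2)CC1`, 10600 nM
compound 2, `Cc1cc(N2CCN(C(C)C)CC2)nc2ccc(NC(=O)c3ccc(Cl)c(Cl)c3)cc12`, 6680 nM

Both compounds were tested in a functional assay on SK-BR-3 cells (Homo sapiens) for antiproliferative activity, read by MTT assay, with a stated time of 72 h; on this read-out lower numbers stand for stronger inhibition and higher numbers for weaker inhibition. Compound 1 gives 10600 nM in this assay, and compound 2 gives 6680 nM. Of the two numbers shown, compound 1 carries the larger one, but its gap to compound 2 lies within the scatter of repeated measurements, so the two compounds cannot be told apart, and nothing can be said of a direction between them.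

Compound 3, `CCN1CCN(c2cc(C)c3cc(NC(=O)c4ccccc4OC)ccc3n2)CC1`, has not yet been measured. It differs from compound 1 at a single point: 2-methoxyphenyl in place of pyridin-3-yl on a carbonyl carbon. The shared core and the amide linkage stay as they are.

Among the compounds with values here, no step between two measured compounds is available to size this change. With only compound 1 and compound 2 as anchors, both at similar weak values, compound 3 is expected to fall near them; the step of a 1.3-fold lower number from compound 1 to compound 3 (0.12 log units; within the scatter) is estimated to lie within the scatter. Compound 3 is therefore estimated at 8000 nM, with a range from 2500 nM to 25000 nM.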

Compound 3, half-maximal inhibitory concentration: 15700 nM
Beside the measured number, compound 3's estimate is 2.0-fold (0.29 log units) below it; measured number inside the range.
By their numbers in this assay, from the lowest: compounds 2, 1 and 3 (each within the scatter of the next, the first and the last beyond it).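

In this assay, the exchange of pyridin-3-yl for 2-methoxyphenyl on a carbonyl carbon gives a 1.5-fold higher number from compound 1 to compound 3 (0.17 log units; within the scatter), the first step measured at this position with everything else held the same. Replacing a ring with one hetero atom by a ring of carbon only that also carries a methoxy group therefore leaves compound 1 and compound 3 indistinguishable in this cell read-out, so this single exchange gives no sign that either group is preferred here. Nothing available explains this outcome or ties it to any feature of either group.

Compound 2 differs from compound 3 in more than one place, so the gap between their numbers cannot be assigned to the group on the carbonyl carbon or to the other difference between them. As far as these compounds go, it remains open whether a different kind of group on that carbon, such as an aminomethylphenyl group, a carboxylic acid on the phenyl ring or a longer alkyl chain in place of the ring, would move the number beyond the scatter.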